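Formyl to Acetyl on the Ring Nitrogen

A few compounds are considered here, and "the series" means these few. Any claim that something is new, unique, unknown or untested is made for them only; others in the source may bear on it.

Three compounds share one core and differ only in the group attached to the amide-type nitrogen. Compound 1 `O=C(N[C@H]1CN(S(=O)(=O)c2ccccc2)C[C@@H]1C(=O)NC[C@@H]1CCCN1)c1cc(-c2ccccc2Cl)on1` gives 22 uL/min in an ADME assay on cells (Hepatocyte, Rattus norvegicus) for metabolic stability; a lower number here means slower removal, a higher number faster removal of the compound. Compound 2 `CN1CCC[C@H](NC(=O)[C@H]2CN(S(=O)(=O)c3ccccc3)C[C@@H]2NC(=O)c2cc(-c3ccccc3Cl)on2)C1` gives 31 uL/min in this assay, a change of a 1.4-fold higher number from compound 1 to compound 2 (0.15 log units; within the scatter). Compound 3 `O=CN1CCC[C@H](NC(=O)[C@H]2CN(S(=O)(=O)c3ccccc3)C[C@@H]2NC(=O)c2cc(-c3ccccc3Cl)on2)C1` gives 97 uL/min in this assay, the highest of the three numbers; its nearest neighbour is compound 2, and the gap is a 3.1-fold higher number from compound 2 to compound 3 (0.50 log units; beyond the scatter), while against compound 1 the gap is a 4.4-fold higher number from compound 1 to compound 3 (0.64 log units; beyond the scatter).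

Compound 4 `CC(=O)N1CCC[C@H](NC(=O)[C@H]2CN(S(=O)(=O)c3ccccc3)C[C@@H]2NC(=O)c2cc(-c3ccccc3Cl)on2)C1` has not yet been measured. It differs from compound 3 by methyl in place of hydrogen on a carbonyl carbon. Going by the values given here, the only measured step that touches the same position is the one from compound 2 to compound 3, where formyl replaced methyl on an amine nitrogen in a ring and gave a 3.1-fold higher number from compound 2 to compound 3 (0.50 log units; beyond the scatter). That step swapped one kind of group for another; the present step keeps the carbonyl in place and merely lengthens it by one carbon, so a smaller shift than that seen between compound 2 and compound 3 is expected, in either direction, and most plausibly none beyond the scatter. On that basis compound 4 is estimated to give 75 uL/min in this assay, within a range of 35 uL/min to 160 uL/min, a step of a 1.3-fold lower number from compound 3 to compound 4 (0.11 log units; within the scatter).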

Compound 4, intrinsic clearance in a liver preparation (reported as CLH), per the amount of preparation that the assay uses: 196 uL/min
Compound 4: the middle estimate sits 2.6-fold (0.42 log units) below what was measured; the measured number lies above the stated range.
By their numbers in this assay, from the lowest: compounds 1 and 2 (each within the scatter of the next); then compound 3; then compound 4.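

Adding one methyl to the carbonyl carbon, which turns formyl into acetyl on the ring nitrogen, is enough to move the result in this assay, giving a 2.0-fold higher number from compound 3 to compound 4 (0.31 log units; beyond the scatter). Going by these compounds alone, this position therefore responds not only to replacing a methyl with a carbonyl group, as the earlier compounds showed, but also to a small change on the carbonyl itself. Across the three groups on this ring nitrogen, the numbers rise from methyl through formyl to acetyl, with the whole span being a 6.3-fold higher number from compound 2 to compound 4 (0.80 log units; beyond the scatter), while 1-acetylpiperidin-3-yl in place of (pyrrolidin-2-yl)methyl gives an 8.9-fold higher number from compound 1 to compound 4 (0.95 log units; beyond the scatter), and nothing available here explains why this single carbon matters.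

The compounds shown leave open whether a longer acyl group such as propanoyl would push the number higher still or whether the rise stops at acetyl. They also leave open what happens when the ring nitrogen carries a methanesulfonyl group or only a hydrogen, which would test whether a carbonyl there goes with the higher numbers.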